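This account rests on a few compounds, and the source may have more. Where it says the series, first, only, none or still open, it means among the compounds named here.

Compounds measured in a functional assay on MGC-803 cells (Homo sapiens) for inhibition, read by MTT assay, with a stated time of 72 h; a lower number here means a stronger inhibitor, a higher number a weaker inhibitor:
- compound 1 `O=C(CSc1nc(Nc2ccccc2)c2ccccc2n1)Nc1ccc(C(F)(F)F)cc1`: 8670 nM
- compound 2 `O=C(CSc1nc(Nc2ccccc2)c2ccccc2n1)Nc1ccc(Cl)cc1Cl`: 12300 nM
- compound 3 `C=CC(=O)Nc1cccc(NC(=O)CSc2nc(Nc3ccccc3Cl)c3ccccc3n2)c1`: 20700 nM

Compound 3 sits at the high end of the three numbers. Against compound 2 its value lies within the scatter; against compound 1 the gap is beyond it, so compound 3 is the weaker inhibitor of those two.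

Compound 4 `C=CC(=O)Nc1cccc(NC(=O)CSc2nc(Nc3ccc(F)c(Cl)c3)c3ccccc3n2)c1` is not yet measured. It differs from compound 3 by 3-chloro-4-fluorophenyl in place of 2-chlorophenyl on a nitrogen on an aromatic ring. Among the compounds with values here, the one measured step, a 1.4-fold higher number from compound 1 to compound 2 (0.15 log units; within the scatter), concerns a change on an amide-type nitrogen, not the nitrogen on the aromatic ring touched here; it therefore bears only loosely on the present change, and it was within the scatter. Within the data shown here, no measured pair varies the group on the nitrogen on the aromatic ring, so nothing points to a shift in either direction beyond the scatter.

For compound 4 the expectation is a value near that of compound 3, estimated at 20000 nM with a range of 8000 nM to 50000 nM. The expected step is a 1.0-fold lower number from compound 3 to compound 4 (0.01 log units; within the scatter), an estimate of no change beyond the scatter.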

Compound 4, half-maximal inhibitory concentration: 7850 nM
Compound 4: the middle estimate sits 2.5-fold (0.41 log units) above what was measured; measured number below the stated range.
By their numbers in this assay, from the lowest: compounds 4, 1, 2 and 3 (each within the scatter of the next, the first and the last beyond it).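

In this assay, the group on the nitrogen on an aromatic ring can shift the number: 3-chloro-4-fluorophenyl in place of 2-chlorophenyl gives a 2.6-fold lower number from compound 3 to compound 4 (0.42 log units; beyond the scatter) and this modest step lies beyond the scatter. Within the data shown here, the only earlier step, a 1.4-fold higher number from compound 1 to compound 2 (0.15 log units; within the scatter) on an amide-type nitrogen, lay within the scatter, so this is the first single change to exceed it. No measurement at hand accounts for the size or direction of the step.

The shown compounds do not separate the contribution of the 3-chloro from that of the 4-fluoro substituent, since the two aryl groups differ in both at once. Also open, as far as these compounds go, is how a 4-methoxyphenyl group or a saturated ring such as cyclohexyl would behave on this nitrogen.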